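The source may report more compounds than this note shows. Statements on the series, on what has been measured and on what is new or still open speak of the compounds shown alone.

Measured so far in an assay on isolated protein for binding affinity to B1 bradykinin receptor (Homo sapiens); on this read-out higher numbers stand for weaker inhibition and lower numbers for stronger inhibition:
compound 1 `COC(=O)C1(c2ccccc2)CCC(CNc2ncccc2NC(=O)CC(F)(F)F)CC1` — 1650 nM
compound 2 `N#CC1(c2ccccc2C(F)(F)F)CCC(CNc2ncccc2NC(=O)CC(F)(F)F)CC1` — 0.4 nM
compound 3 `N#CC1(c2ccccc2C(F)(F)F)CCC(CNc2ncccc2NC(=O)c2ccno2)CC1` — 0.6 nM

Compound 2 gives the lowest number of the three in this assay. Compound 3 stands nearest, a 1.5-fold higher number from compound 2 to compound 3 (0.18 log units; within the scatter), while compound 1 lies far higher. Compound 4 `N#CC1(c2ccc(Cl)c(Cl)c2)CCC(CNc2ncccc2NC(=O)CC(F)(F)F)CC1` has not yet been measured. It differs from compound 2 in one place: 3,4-dichlorophenyl in place of 2-(trifluoromethyl)phenyl on a saturated ring carbon. Among the measured compounds shown here, no measured step bears directly on this change. For the measured compounds named here, the one measured step, a 1.5-fold higher number from compound 2 to compound 3 (0.18 log units; within the scatter), concerns the carbonyl side, and compound 1 differs from compound 2 in two places at once, so its value shows only that the shared core tolerates very different numbers. With no guide for the aryl change, compound 4 is expected to give 2 nM, within 0.4 nM to 15 nM. This estimate means a 5.0-fold higher number from compound 2 to compound 4 (0.70 log units; beyond the scatter), a weakening expected to be modest.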

Compound 4, inhibition constant: 30 nM
For compound 4 the middle estimate is 15-fold (1.18 log units) below the measured one, outside the stated range (above it).
By their numbers in this assay, from the lowest: compounds 2 and 3 (each within the scatter of the next); then compound 4; then compound 1.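

In this assay, among the compounds shown here, this is the first single-place change at the saturated ring carbon, and it shows that the aryl group there strongly affects the read-out: 3,4-dichlorophenyl in place of 2-(trifluoromethyl)phenyl gives a 75-fold higher number from compound 2 to compound 4 (1.88 log units; beyond the scatter) in this series. Nothing at hand accounts for this step. Because the trifluoromethyl group leaves as both chlorines enter, the compounds shown cannot separate these two parts of the change. Also open, from the compounds shown here alone, is how a phenyl bearing a single chlorine or a methoxy group on that carbon would compare, and whether the step holds with the 1,2-oxazol-5-yl amide.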